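The source may report more compounds than this note shows. Statements on the series, on what has been measured and on what is new or still open speak of the compounds shown alone.

In a functional assay on SW1573 cells (Homo sapiens) for inhibition, read by sulforhodamine B assay, with a stated time of 48 h (a lower number here means a stronger inhibitor of growth, a higher number a weaker inhibitor of growth), a small set of esters sharing a large oxygen-rich ring core were compared. Compound 1 `CC(C)=CC1C(C(=O)OCC2COCCOCCOCCOCCOCCO2)C1(C)C` gives 54000 nM in this assay. Compound 2 `O=C(CCCCCCCCCCOc1ccccc1)OCC1COCCOCCOCCOCCOCCO1` gives 24000 nM in this assay, so compound 1 stands as the higher, that is weaker, of the two measured numbers, and the gap between them lies beyond the usual scatter of repeated measurements. Compound 3 `O=C(CCCCC1CCCCC1)OCC1COCCOCCOCCO1` gives > 100000 nM in this assay, and this is a limit of the assay rather than a measured number; it marks (the limit of > 100000 nM in this assay, at which 1 of the 3 values shown sits).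

Compound 4 `O=C(OCC1COCCOCCOCCOCCOCCO1)c1cccnc1` has not yet been measured. It differs from compound 1 in one place: pyridin-3-yl in place of 2,2-dimethyl-3-(2-methylprop-1-en-1-yl)cyclopropyl on a carbonyl carbon. The cyclopropyl group with its double bond leaves, and an aromatic pyridin-3-yl ring carrying one hydrogen-bond acceptor enters on the carbonyl carbon whose other neighbour is the oxygen next to a carbonyl group.

Within the data shown here, no measured pair shows a step of this kind, so the expectation rests on the weak inhibition seen throughout the set. The step is expected to lead toward a weaker inhibitor, near the limit, estimated as a 1.5-fold higher number from compound 1 to compound 4 (0.17 log units; within the scatter). Compound 4 is therefore expected to give about 80000 nM, with a likely range from 25000 nM to 200000 nM.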

Compound 4, concentration for 50% growth inhibition: > 100000 nM
Compound 4: a limit, no number; the forecaster's own chance of this, stated with the estimate: 45%; at least 1.2-fold (0.09 log units) between middle value and limit.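

In this assay compound 4 gives > 100000 nM, which is a limit of the assay and not a number. Placing pyridin-3-yl on the carbonyl carbon instead of 2,2-dimethyl-3-(2-methylprop-1-en-1-yl)cyclopropyl gives an at least 1.8-fold higher number from compound 1 to compound 4 (0.26 log units; that floor lies within the scatter), so only a floor for this change is known, and its true size stays undetermined. This first comparison at a single position shows that an aromatic ring carrying a hydrogen-bond acceptor brings no gain in growth inhibition here, and compound 4 joins compound 3 at the assay's limit: the limit of > 100000 nM in this assay, at which 2 of the 4 values shown sit.

The compounds shown leave open whether the ring nitrogen matters at all, since a plain phenyl ring on the same carbonyl carbon would be needed to separate its effect from the loss of the cyclopropyl group and its double bond. They also leave open how this position would respond to a group of a different kind, such as an amine or a carboxylic acid at the end of a longer chain.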